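The source may report more compounds than this note shows. Statements on the series, on what has been measured and on what is new or still open speak of the compounds shown alone.

Within the data shown here, compound 3 `CCCCCc1ccc(-c2cn(C[C@H](O)[C@H]3OC(=O)C(OCc4ccccc4)=C3OCc3ccccc3)nn2)cc1` carries a 4-pentylphenyl on the shared core; in a functional assay on A549 cells (Homo sapiens) for antiproliferative activity, read by MTT assay, with a stated time of 72 h (on this read-out higher numbers stand for weaker inhibition and lower numbers for stronger inhibition), compound 3 gives 6220 nM, the second highest of the three numbers known. Compound 1 `O=C1O[C@H]([C@@H](O)Cn2cc(-c3ccc(Br)cc3)nn2)C(OCc2ccccc2)=C1OCc1ccccc1` gives 750 nM, and compound 2 `O=C1O[C@H]([C@@H](O)Cn2cc(-c3cccc(O)c3)nn2)C(OCc2ccccc2)=C1OCc1ccccc1` gives 59900 nM. The measured steps are an 80-fold higher number from compound 1 to compound 2 (1.90 log units; beyond the scatter), an 8.3-fold higher number from compound 1 to compound 3 (0.92 log units; beyond the scatter) and a 9.6-fold lower number from compound 2 to compound 3 (0.98 log units; beyond the scatter). Compound 4 `COc1ccccc1-c1cn(C[C@H](O)[C@H]2OC(=O)C(OCc3ccccc3)=C2OCc2ccccc2)nn1` differs from compound 3 by 2-methoxyphenyl in place of 4-pentylphenyl on an aromatic carbon. Among the measured compounds shown here, no measured step involves a methoxy group, so the change is only loosely bracketed by the aryl swaps seen so far, which ranged from modest to large. A modest step in either direction is therefore expected, bounded by compound 2, which showed 59900 nM, and compound 1, which gave 750 nM. Compound 4 is expected to give 3000 nM, between 600 nM and 15000 nM, which would mean a 2.1-fold lower number from compound 3 to compound 4 (0.32 log units; beyond the scatter).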

Compound 4, half-maximal inhibitory concentration: > 100000 nM
Compound 4 ended at the assay's limit (the forecaster's own chance of this, stated with the estimate: 5%); middle value at least 33-fold (1.52 log units) from the limit.
By their numbers in this assay, from the lowest: compound 1; then compound 3; then compound 2. At a limit, above all of these: compound 4.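

Compound 4 reads only as a limit, > 100000 nM in this assay, so every step to it is a floor: the limit of > 100000 nM in this assay, at which 1 of the 4 values shown sits.

Among these compounds, this aromatic carbon tolerates less than the earlier compounds showed, with an at least 16-fold higher number from compound 3 to compound 4 (1.20 log units; beyond the scatter) and an at least 130-fold higher number from compound 1 to compound 4 (2.12 log units; beyond the scatter). The remaining comparison, an at least 1.6-fold higher number from compound 2 to compound 4 (0.22 log units; that floor lies within the scatter), does not separate those two compounds.

The compounds shown leave open whether the methoxy group itself or its location on the phenyl ring matters. On these data alone, how an amine or a chlorine on that ring would read also stays open.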